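Anilino versus benzylamino on the shared core

This account rests on a few compounds, and the source may have more. Where it says the series, first, only, none or still open, it means among the compounds named here.

Measured compounds:
- compound 1 `Nc1ccccc1NC(=O)/C=C/c1ccc(Cn2cnc3c(Nc4ccccc4)nc(Cl)nc32)cc1`: 41.9%
- compound 2 `Nc1ccccc1NC(=O)c1ccc(Cn2cnc3c(Nc4ccccc4)nc(Cl)nc32)cc1`: 74.8%
- compound 3 `CCC(C)n1cnc2c(NCc3ccc(C(=O)Nc4ccccc4N)cc3)nc(Cl)nc21`: 65%

In a functional assay on HepG2 cells (Homo sapiens) for antiproliferative activity, read by CCK-8 assay, with a stated time of 72 h, tested at 8 uM (a higher number here means a stronger effect of the compound at the concentration tested, a lower number a weaker effect), compound 2 gives 74.8%, the highest of the three numbers. Compound 3 gives 65%, which lies within the scatter of compound 2; compound 1 gives 41.9%, beyond the scatter below it. Going by the values given here, the only measured single-point step is a number 32.9 percentage points higher from compound 1 to compound 2 (beyond the scatter), and it concerns the linker to the amide, not the group on the nitrogen.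

Compound 4 `Nc1ccccc1NC(=O)c1ccc(Cn2cnc3c(NCc4ccccc4)nc(Cl)nc32)cc1` is the next compound. The change from compound 2 is benzyl in place of phenyl on a nitrogen on an aromatic ring. Among the compounds with values here, no measured step isolates this change. Compound 3 carries the benzylamino group, but also a different substituent on the core, so its value only shows that a benzylamino compound of this series sits within the scatter of compound 2. Within the data shown here, since the one measured step bears on a different site, no step beyond the scatter is expected in this assay; the expected step is a number 6.8 percentage points lower from compound 2 to compound 4 (within the scatter). Compound 4 is estimated at 68%, with a range from 50% to 85%.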

Compound 4, a percentage reported as inhibition, at one concentration (the size of the read-out at that concentration, not a potency): 62.8%
The estimate for compound 4 lay 5.2 percentage points above the measured number, and the stated range covers the measured number.
By their numbers in this assay, from the lowest: compound 1; then compounds 4, 3 and 2 (each within the scatter of the next, the first and the last beyond it).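

In this assay, the nitrogen on the aromatic ring now has a step of its own: the change from anilino to benzylamino gives a number 12 percentage points lower from compound 2 to compound 4 (beyond the scatter) on an otherwise unchanged structure. The earlier single-point step concerned only the linker to the amide, so it could not show that this position responds to the change; here the response is modest, and compound 4 still gives 62.8% at the concentration tested. Nothing available explains this step.

As far as these compounds go, whether the ring itself or the length of the chain joining it to the nitrogen drives the step stays open, and a phenethyl, cyclohexyl or simple methyl group on this nitrogen would help to separate the two. Also open is whether the step carries over to compounds with the other core substituent seen in compound 3, which has no anilino counterpart among the compounds shown.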